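A few compounds are considered here, and "the series" means these few. Any claim that something is new, unique, unknown or untested is made for them only; others in the source may bear on it.

Measured so far in a functional assay on PC-3 cells (Homo sapiens) for cytotoxicity, read by MTT assay, with a stated time of 72 h; on this read-out lower numbers stand for stronger inhibition and higher numbers for weaker inhibition:
compound 1 `CC1=C(/C=C/C(=O)/C=C/c2ccccc2F)C(C)(C)CCC1O` gives 10400 nM
compound 2 `CC1=C(/C=C/C(=O)/C=C/c2ccc(F)cc2)C(C)(C)CCC1O` gives 6200 nM
compound 3 `CC1=C(/C=C/C(=O)/C=C/c2cccc(C)c2)C(C)(C)CCC1O` gives 6200 nM

Compound 3 stands level with compound 2 at the digits shown, and the two together hold the lowest numbers of the three. The step of no change at the digits printed from compound 2 to compound 3 (within the scatter) and the step of a 1.7-fold lower number from compound 1 to compound 3 (0.22 log units; within the scatter) are both within the scatter, as is a 1.7-fold lower number from compound 1 to compound 2 (0.22 log units; within the scatter). The three aryl variations on the chain thus sit inside one band; no ordering among them can be read from this assay.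

Compound 4 `CC1=C(/C=C/C(=O)/C=C/c2cccc(C#N)c2)C(C)(C)CCC1O` differs from compound 3 in one place: cyano in place of methyl on an aromatic carbon. Going by the values given here, no measured step involves a cyano group. The three steps that exist all exchange one aryl substituent for another, and none of them leaves the scatter. Among the compounds with values here, there is no step that would support a movement in either direction for compound 4, and there is no information on a cyano group in this assay. On that basis the expected step is no change at the digits printed from compound 3 to compound 4 (within the scatter), with no direction claimed beyond the scatter. Compound 4 is estimated at 6200 nM in this assay, with a range from 2800 nM to 14000 nM.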

Compound 4, half-maximal inhibitory concentration: 7200 nM
Estimate against measurement, compound 4: 1.2-fold (0.06 log units) below; the measured number falls inside the stated range.
By their numbers in this assay, from the lowest: compounds 2, 3, 4 and 1 (each within the scatter of the next).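

In this assay, going by these compounds alone, the exchange of 3-methylphenyl for 3-cyanophenyl gives the first reading on a nitrile on this aromatic carbon, meta to a large group, and the result is a 1.2-fold higher number from compound 3 to compound 4 (0.06 log units; within the scatter). Set against the two fluorophenyl compounds, the nitrile gives a 1.2-fold higher number from compound 2 to compound 4 (0.06 log units; within the scatter) and a 1.4-fold lower number from compound 1 to compound 4 (0.16 log units; within the scatter), so a substituent with two heavy atoms and a hydrogen-bond acceptor joins methyl and fluorine in the same band, and all the steps among these four compounds stay within the scatter. No independent measurement on these compounds bears on this flat result, and the numbers alone do not say what lies behind it.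

The compounds shown leave open whether any group on this aryl ring can carry the number beyond the scatter, for example an amine or a carboxylic acid in place of the nitrile. Equally open, as far as these compounds go, is what a ketone in place of the hydroxyl on the shared core would do to a band defined so far by aryl exchanges alone.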